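The source may report more compounds than this note shows. Statements on the series, on what has been measured and on what is new or still open speak of the compounds shown alone.

Measured so far in a functional assay on HCT-116 cells (Homo sapiens) for antiproliferative activity, read by MTT assay, with a stated time of 24 h; on this read-out lower numbers stand for stronger inhibition and higher numbers for weaker inhibition:
- compound 1 `C=CCOc1ccc2c(=O)c(-c3cc(OC)c(OC)cc3OC)coc2c1`: 6600 nM
- compound 2 `COc1cc(OC)c(-c2coc3cc(OCc4ccccc4)ccc3c2=O)cc1OC`: 2280 nM

Compound 2 has the lower of the two numbers, at 2280 nM. The next compound, compound 3 `COc1cccc(C(=O)Oc2ccc3c(=O)c(-c4cc(OC)c(OC)cc4OC)coc3c2)c1`, keeps the shared core and differs from compound 2 on a single oxygen: (3-methoxyphenyl)carbonyl in place of benzyl on an oxygen on an aromatic ring. The change is (3-methoxyphenyl)carbonyl in place of benzyl on an oxygen on an aromatic ring, or benzyloxy to ((3-methoxyphenyl)carbonyl)oxy when cut one bond further out.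

Within the data shown here, only one measured step bears on this: a 2.9-fold lower number from compound 1 to compound 2 (0.46 log units; beyond the scatter). That step is modest but beyond the scatter, and it replaced vinyl with phenyl on the saturated chain carbon bound to the same oxygen. Neither compound 1 nor compound 2 has a carbonyl on that oxygen, so the step gives size but no reliable direction. A small upward drift in this assay is the working guess, with no step beyond the scatter expected. The expected change is a 1.3-fold higher number from compound 2 to compound 3 (0.12 log units; within the scatter). For compound 3 the estimated value is 3000 nM, with an expected range of 800 nM to 10000 nM.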

Compound 3, half-maximal inhibitory concentration: > 10000 nM
Compound 3: only a limit was reported (the forecaster's own chance of this, stated with the estimate: 5%); middle value at least 3.3-fold (0.52 log units) away from the limit.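

In this assay, the oxygen on an aromatic ring does not treat all aromatic groups alike: (3-methoxyphenyl)carbonyl in place of benzyl gives an at least 4.3-fold higher number from compound 2 to compound 3 (0.64 log units; beyond the scatter), which runs opposite in direction to the earlier step, a 2.9-fold lower number from compound 1 to compound 2 (0.46 log units; beyond the scatter). Against allyl, the same group gives an at least 1.5-fold higher number from compound 1 to compound 3 (0.18 log units; that floor lies within the scatter), and that floor lies within the scatter, so only the separation from the benzyl compound is established beyond the scatter. Compound 3 sits at a limit of the assay and has no number: the limit of > 10000 nM in this assay, at which 1 of the 3 values shown sits.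

The change brings in the carbonyl and the methoxy group at once, and the compounds shown do not separate the two; a plain benzoyl group or a 3-methoxybenzyl group on the same oxygen would bear on that question. Also open, on these data alone, is how far compound 3 lies past its limit. Equally open, as far as these compounds go, is whether a group of another kind on this oxygen, such as an aminoethyl chain, would keep the number of compound 2 at 2280 nM.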